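A Longer Chain on a Flat Series

The compounds below may be only part of what the source reports. "The series", "measured", "known", "first", "only" and "open" are said of these compounds alone.

compound 1 `CCCCSC[C@H](NC(C)=O)C(=O)CCl` gives 5600 nM as its value
compound 2 `CCCCCSC[C@H](NC(C)=O)C(=O)CCl` gives 5400 nM as its value
compound 3 `CCCCCCCCSC[C@H](NC(C)=O)C(=O)CCl` gives 4100 nM as its value

These values come from a functional assay on MOLT-3 cells (Homo sapiens) (a higher number here means a weaker inhibitor, a lower number a stronger inhibitor), and sit close together. Compound 3 lies within the scatter of both other compounds, so no order among the three can be claimed. Compound 4 `CCCCCCCCCCCCSC[C@H](NC(C)=O)C(=O)CCl` has not been measured yet, and its change from compound 3 is butyl in place of hydrogen on a saturated chain carbon, eight bonds along the chain from a sulfur on the chain.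

The same butyl addition, made four bonds along the chain from a sulfur, gave a 1.4-fold lower number from compound 1 to compound 3 (0.14 log units; within the scatter) as its step. The smaller additions gave a 1.0-fold lower number from compound 1 to compound 2 (0.02 log units; within the scatter) and a 1.3-fold lower number from compound 2 to compound 3 (0.12 log units; within the scatter) as theirs. None of these steps leaves the scatter, so no step beyond the scatter is expected in this assay here, although no measured chain is this long. The expected step is a 1.2-fold lower number from compound 3 to compound 4 (0.07 log units; within the scatter) by this estimate. For compound 4 the expected value is 3500 nM with an estimated range from 1500 nM to 7000 nM in this assay.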

Compound 4, half-maximal inhibitory concentration: 2300 nM
Estimate against measurement, compound 4: 1.5-fold (0.18 log units) above; measured number inside the range.
By their numbers in this assay, from the lowest: compounds 4, 3, 2 and 1 (each within the scatter of the next, the first and the last beyond it).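

In this assay, butyl in place of hydrogen on a saturated chain carbon, eight bonds along the chain from a sulfur, gives a 1.8-fold lower number from compound 3 to compound 4 (0.25 log units; within the scatter) and so stays within the scatter, which means this single change cannot be told apart from no change at all. Heptyl in place of hydrogen, five bonds along the chain from a sulfur, gives a 2.3-fold lower number from compound 2 to compound 4 (0.37 log units; beyond the scatter) and is the only step in this series to pass beyond the scatter, though only modestly. No supporting measurement accompanies these numbers, so the reason for this step remains unknown.

On these data alone, whether a longer chain would lower the number further remains open. So does what an amine or a carboxylic acid in place of the butyl would do in this assay.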